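The compounds below may be only part of what the source reports. "The series", "measured", "known", "first", "only" and "open" are said of these compounds alone.

Compound 1 `Nc1ccccc1NC(=O)c1ccc(CNC(=O)c2cc3cccnc3[nH]2)cc1`: 10000 nM
Compound 2 `Nc1ccccc1NC(=O)c1ccc(NC(=S)NCc2ccccc2F)cc1`: 6300 nM
Compound 3 `Nc1ccccc1NC(=O)c1ccc(Cn2cc(-c3ccc(NC(=O)NCc4cccnc4)cc3)nn2)cc1`: > 100000 nM, a limit of the assay and not a number

These values come from a functional assay on HCT-116 cells (Homo sapiens) for cytotoxicity, read by MTT assay, with a stated time of 72 h; on this read-out lower numbers stand for stronger inhibition and higher numbers for weaker inhibition. Compound 2 and compound 1 lie within the usual scatter of each other, so the data do not separate them.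

Compound 4 `Nc1ccccc1NC(=O)c1ccc(NC(=S)NCc2cncc(Br)c2)cc1` has 5-bromopyridin-3-yl in place of 2-fluorophenyl on a saturated chain carbon bound to an amide-type nitrogen.

Among the compounds with values here, no measured pair of compounds shows this exchange, so the expectation stays close to compound 2 at 6300 nM. The expected result a 1.1-fold lower number from compound 2 to compound 4 (0.02 log units; within the scatter) is no change beyond the scatter, in either direction. For compound 4 the estimated value is 6000 nM, with an expected range of 2000 nM to 20000 nM.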

Compound 4, half-maximal inhibitory concentration: 9200 nM
Compound 4: middle estimate off by 1.5-fold (0.19 log units), on the low side; low and high end bracket the measured number.
By their numbers in this assay, from the lowest: compounds 2, 4 and 1 (each within the scatter of the next). At a limit, above all of these: compound 3.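

In this assay, putting 5-bromopyridin-3-yl in place of 2-fluorophenyl on a saturated chain carbon bound to an amide-type nitrogen gives a 1.5-fold higher number from compound 2 to compound 4 (0.16 log units; within the scatter). This first step at the position shows that a ring nitrogen, a hydrogen-bond acceptor and bromine can enter together, and the fluorine can leave, with no change the assay can separate. Nothing measured here accounts for this step.

From the compounds shown here alone, the ring nitrogen and the bromine enter together, so their separate contributions remain unknown. Going by these compounds, whether a carboxylic acid or an amine on this ring would shift the number also stays open.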